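Sulfonyl substituent variation on the shared core

The compounds below may be only part of what the source reports. "The series", "measured", "known", "first", "only" and "open" are said of these compounds alone.

The series keeps one core and varies the group on the amine nitrogen. Compound 1 `CCCCCS(=O)(=O)N[C@@H](CNC(=O)c1ccc2c(c1)C(=O)N(CCC1CCNCC1)C2)C(=O)O` carries a pentylsulfonyl group; in a functional assay for inhibition, with Homo sapiens as the target (a higher number here means a weaker inhibitor, a lower number a stronger inhibitor), compound 1 gives 9 nM. Compound 2 `O=C(NCc1ccccc1)N[C@@H](CNC(=O)c1ccc2c(c1)C(=O)N(CCC1CCNCC1)C2)C(=O)O` carries a benzylcarbamoyl group and gives 10 nM; compound 3 `O=C(NC[C@H](NS(=O)(=O)c1cccs1)C(=O)O)c1ccc2c(c1)C(=O)N(CCC1CCNCC1)C2` carries a (thiophen-2-yl)sulfonyl group and gives 7 nM. Among these three numbers compound 1 stands second highest, with a 1.1-fold higher number from compound 1 to compound 2 (0.05 log units; within the scatter) on one side and a 1.3-fold lower number from compound 1 to compound 3 (0.11 log units; within the scatter) on the other, both within the scatter; the remaining pair shows a 1.4-fold lower number from compound 2 to compound 3 (0.15 log units; within the scatter), also within the scatter.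

Compound 4 `O=C(NC[C@H](NS(=O)(=O)Cc1ccccc1)C(=O)O)c1ccc2c(c1)C(=O)N(CCC1CCNCC1)C2` differs from compound 1 by phenyl in place of butyl on a saturated chain carbon bound to a sulfonyl sulfur. Going by the values given here, two measured steps bear on this: a 1.3-fold lower number from compound 1 to compound 3 (0.11 log units; within the scatter), where an aromatic ring enters on the sulfonyl sulfur, and a 1.1-fold higher number from compound 1 to compound 2 (0.05 log units; within the scatter), where a benzyl group enters on the amine nitrogen. Neither reaches beyond the scatter, so for this assay the expectation is no step beyond the scatter in either direction, which is what a 1.1-fold lower number from compound 1 to compound 4 (0.05 log units; within the scatter) expresses. Compound 4 is therefore estimated at 8 nM, within 4 nM to 18 nM.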

Compound 4, half-maximal inhibitory concentration: 4 nM
For compound 4 the middle estimate is 2.0-fold (0.30 log units) above the measured one; the measured number falls inside the stated range.
By their numbers in this assay, from the lowest: compounds 4, 3, 1 and 2 (each within the scatter of the next, the first and the last beyond it).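

Going by these compounds alone, at the saturated chain carbon bound to a sulfonyl sulfur, phenyl in place of butyl gives the first step at this position in this assay that lies beyond the scatter (a 2.3-fold lower number from compound 1 to compound 4 (0.35 log units; beyond the scatter)), though it is modest. Benzylsulfonyl in place of benzylcarbamoyl on the amine nitrogen also gives a modest step beyond the scatter (a 2.5-fold lower number from compound 2 to compound 4 (0.40 log units; beyond the scatter)). Benzyl in place of thiophen-2-yl on the sulfonyl sulfur stays within it (a 1.8-fold lower number from compound 3 to compound 4 (0.24 log units; within the scatter)), so these two sulfonyl substituents cannot be separated here. No supporting data bear on the reason for these steps.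

Open, as far as these compounds go, is whether a longer chain linking the sulfonyl sulfur to the phenyl ring would keep or lose the step seen with compound 4. Also open, from the compounds shown here alone, is how an amine or a carboxylic acid on that phenyl ring would read in this assay.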